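This account rests on a few compounds, and the source may have more. Where it says the series, first, only, none or still open, it means among the compounds named here.

Measured so far in a functional assay on PC-3 cells (Homo sapiens) for cytotoxicity; on this read-out higher numbers stand for weaker inhibition and lower numbers for stronger inhibition:

- compound 1 `COc1ccc(Cn2cc(/C=N\NC(=O)c3c[nH]c4ccccc34)c3cc(OC)ccc32)cc1`: 13600 nM
- compound 2 `Cn1cc(C(=O)N/N=C\c2cn(Cc3ccc(Cl)cc3)c3cc(F)ccc23)c2ccccc21`: 22100 nM

Compound 2 stands at the higher of the two numbers in this assay, with compound 1 the nearer neighbour; the gap between the two lies within the usual scatter of repeated measurements, so the two values are read as alike. Both are weak inhibitors on this read-out.

Compound 3 `O=C(N/N=C\c1cn(Cc2ccc(Cl)cc2)c2cc(F)ccc12)c1c[nH]c2ccc(Br)cc12` is the next member and is not yet measured in this assay. Compared with compound 2 the change is 5-bromo-1H-indol-3-yl in place of 1-methyl-1H-indol-3-yl on a carbonyl carbon. The rest of the molecule, including the chloro-benzyl substituent and the fluorine on the shared core, is kept.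

Going by the values given here, no directly comparable step between measured compounds exists for this exchange, so the size of the step can only be guessed. Compound 1, which also carries a 1H-indol-3-yl bearing a free ring hydrogen on the carbonyl carbon, gives 13600 nM, close to compound 2. The expectation for compound 3 is therefore a step of a 1.5-fold lower number from compound 2 to compound 3 (0.17 log units; within the scatter) in this assay, that is, no change beyond the scatter, with a slight lean toward stronger inhibition. Compound 3 is estimated at 15000 nM, in the range 5000 nM to 45000 nM.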

Compound 3, half-maximal inhibitory concentration: 12400 nM
Estimate against measurement, compound 3: 1.2-fold (0.08 log units) above; the range from low to high includes it.
By their numbers in this assay, from the lowest: compounds 3, 1 and 2 (each within the scatter of the next).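

In this assay, going by these compounds alone, the exchange of 1-methyl-1H-indol-3-yl for 5-bromo-1H-indol-3-yl on a carbonyl carbon gives a 1.8-fold lower number from compound 2 to compound 3 (0.25 log units; within the scatter), so compound 2 and compound 3 are read as alike, and this is the first step that can be read at this position. The exchange alters two things at once, since the entering group carries a bromine and a hydrogen-bond donor that the leaving group lacks, and taken together they stay within the scatter on this read-out. No measurement bears on why the read-out holds across this exchange.

The separate contributions remain open, as the unsubstituted 1H-indol-3-yl group and 5-bromo-1-methyl-1H-indol-3-yl, which would split the bromine from the methyl, are not among the compounds shown. Also open, from the compounds shown here alone, is whether any group on this carbonyl carbon can move the value beyond the scatter, for instance a simple phenyl ring, or a chain ending in an amine or a carboxylic acid in place of the indole.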